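The compounds below may be only part of what the source reports. "The series", "measured", "known", "first", "only" and "open" are said of these compounds alone.

Three close analogues share one core and differ only in the aryl group on the carbonyl carbon. Compound 1 `O=C(/C=C/c1ccc2c(c1)B(O)OC2)c1cccc(F)c1` was tested in an ADME assay on L929 cells (Mus musculus) for cytotoxicity, read by resazurin assay, with a stated time of 72 h; a lower number here means a stronger inhibitor, a higher number a weaker inhibitor. In this assay compound 1 gives only a limit, > 10 ug/mL. Compound 2 `CSc1ccc(C(=O)/C=C/c2ccc3c(c2)B(O)OC3)cc1` in this assay likewise gives only a limit, > 10 ug/mL. Compound 3 `Nc1ccc(C(=O)/C=C/c2ccc3c(c2)B(O)OC3)cc1` in this assay also returns only a limit, > 10 ug/mL. Compound 3 therefore stands at the same limit as the two others, and no number sets it apart from them. The step that the two limits leave unreadable from compound 1 to compound 3 and the step that the two limits leave unreadable from compound 2 to compound 3 cannot be sized, because of the limit of > 10 ug/mL in this assay, at which 3 of the 3 values shown sit. Compound 4 `O=C(/C=C/c1ccc2c(c1)B(O)OC2)c1ccc(Cl)cc1` has not yet been measured in this assay. Compared with compound 3 it shows (chloro in place of amino on an aromatic carbon). Both measured steps touch the same position of the same ring, but neither gives a readable size, so no direction beyond the scatter can be drawn from them. It is expected that compound 4 behaves as the three measured compounds did, with the step that the limit leaves unreadable from compound 3 to compound 4 most likely unreadable again. The estimate for compound 4 in this assay is 20 ug/mL, between 8 ug/mL and 60 ug/mL.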

Compound 4, half-maximal inhibitory concentration: > 10 ug/mL
Compound 4: no number, only a limit; the forecaster's own chance of this, stated with the estimate: 80%; the middle value is on the limit's open side.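

Compound 4 also returns only a limit in this assay, so none of its steps from compound 1, compound 2 or compound 3 can be read: the limit of > 10 ug/mL in this assay, at which 4 of the 4 values shown sit. The compounds shown leave open how the four compare in this assay, and whether any aryl group on the carbonyl carbon would give a measured number there.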